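Aryl Swap on the Branched Chain: Thiazole Variant

The source may report more compounds than this note shows. Statements on the series, on what has been measured and on what is new or still open speak of the compounds shown alone.

Measured so far:
compound 1 `CC(CC(=O)NC(=N)NCCCc1c[nH]cn1)c1cccs1` — 38 nM
compound 2 `CC(CC(=O)NC(=N)NCCCc1c[nH]cn1)c1ccccn1` — 38 nM

Compound 2 stands level with compound 1 in a functional assay on cardiac atrium for agonist activity at histamine H2 receptor (Cavia porcellus); a higher number here means that more compound is needed for the effect, a lower number that less compound is needed: the step of no change at the digits printed from compound 1 to compound 2 (within the scatter) is inside the scatter, so the two values are not ordered. Compound 3 `CC(CC(=O)NC(=N)NCCCc1c[nH]cn1)c1nccs1` is the next member awaiting measurement in this assay. Its difference from compound 2 is 1,3-thiazol-2-yl in place of pyridin-2-yl on a saturated chain carbon bound to two saturated chain carbons. Within the data shown here, the only step bearing on this exchange is the one from compound 1 to compound 2, which also swaps the aryl group on the same chain carbon, and that step was no change at the digits printed from compound 1 to compound 2 (within the scatter). Replacing one aromatic ring by another at this position has so far left the read-out unchanged, and nothing in the two measured compounds points in either direction for compound 3. Compound 3 is therefore expected to sit close to compound 2, with an expected step of a 1.1-fold higher number from compound 2 to compound 3 (0.02 log units; within the scatter) not beyond the scatter; the estimate for compound 3 is 40 nM, within 18 nM to 90 nM.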

Compound 3, half-maximal effective concentration: 38.9 nM
Compound 3: middle estimate off by 1.0-fold (0.01 log units), on the high side; low and high end bracket the measured number.
By their numbers in this assay, from the lowest: compounds 1, 2 and 3 (each within the scatter of the next).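

In this assay, 1,3-thiazol-2-yl joins the aryl exchanges on the saturated chain carbon bound to two saturated chain carbons, with a 1.0-fold higher number from compound 2 to compound 3 (0.01 log units; within the scatter) against pyridin-2-yl and a 1.0-fold higher number from compound 1 to compound 3 (0.01 log units; within the scatter) against thiophen-2-yl. The read-out therefore stays level across all three compounds, and this exchange adds something the first pair did not show: the move from a six-membered to a five-membered aromatic ring, with the difference in hydrogen-bond acceptors between pyridin-2-yl and 1,3-thiazol-2-yl, opens no gap beyond the scatter. No supporting data are available to explain this agreement.

On these data alone, all three groups here are aromatic rings, so it remains open whether the read-out holds with cyclohexyl in the same place. The same question stands for a group carrying an amine or a carboxylic acid.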